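The source may report more compounds than this note shows. Statements on the series, on what has been measured and on what is new or still open speak of the compounds shown alone.

Of the compounds shown here, three have so far been tested in a physicochemical assay for solubility, read by nephelometry, in phosphate buffer, measured as kinetic solubility, at pH 7.4; a higher number here means a more soluble compound, a lower number a less soluble compound. Compound 2 (`CCOC(=O)c1oc2ccccc2c1C`) gives 200000 nM. Compound 3 (`Cc1c(-c2c3c(N)n[nH]c(=O)c3nn2-c2ccc(NC(=O)/C=C/CN(C)C)cc2)oc2ccc(Cl)cc12`) gives 200000 nM, so the two stand level within the usual scatter. Compound 1 (`C=CC(=O)Nc1ccc(-n2nc3c(=O)[nH]nc(N)c3c2-c2oc3ccc(C)cc3c2C)cc1`) gives 20000 nM, a lower number, and its gap to compound 2 lies beyond the scatter. Compound 2 therefore shares the upper level of this small set with compound 3.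

The next compound to be measured is compound 4 (`CCOC(=O)c1oc2ccc(C)cc2c1C`). It differs from compound 2 in a single place, with methyl in place of hydrogen on an aromatic carbon. Within the data shown here, no measured pair of compounds differs by this change alone, so the data offer no direct guide to its size. Compound 1 and compound 3 differ from compound 2 in many places at once, and their values cannot be assigned to any single group.

This is a small structural change, so only a modest shift is anticipated. The expected step in this assay is small and downward, a 1.7-fold lower number from compound 2 to compound 4 (0.22 log units; within the scatter), and it may well stay within the scatter. For compound 4 the estimated value is 120000 nM, with an expected range from 40000 nM to 250000 nM.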

Compound 4, solubility: 200000 nM
For compound 4 the middle estimate is 1.7-fold (0.22 log units) below the measured one, and the stated range covers the measured number.
By their numbers in this assay, from the lowest: compound 1; then compounds 2, 3 and 4 (each within the scatter of the next).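

Among these compounds, compound 2 and compound 4 form the first measured pair that differs by one change alone, so the size of this change in this assay can now be read directly rather than estimated. Methyl in place of hydrogen on this aromatic carbon, meta to a fused ring and para to a fused ring, gives no change at the digits printed from compound 2 to compound 4 (within the scatter), so in this pair the added carbon leaves the read-out where it was. No measurement at hand speaks to why the number holds steady here.

This is one step at one position in one small compound, so it says nothing yet about other aromatic carbons of the same ring, or about a larger or different group on this carbon, such as an amine, a carboxylic acid or a longer chain. It also leaves open whether the same methyl change would give a similar step in the much larger compounds, such as compound 1 and compound 3, which differ from compound 2 in many places at once and so offer no reading of this change.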